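Phenethyl to propyl: shortening the chain of compound 3

The compounds below may be only part of what the source reports. "The series", "measured", "known", "first", "only" and "open" are said of these compounds alone.

The working set holds compound 1 `CC(C)C[C@H](NC(=O)[C@H](CC(C)C)NC(=O)N1C/C(=C\c2ccc(F)cc2)C(=O)/C(=C/c2ccc(F)cc2)C1)B1OC(C)(C)C(C)(C)O1` and compound 2 `CC(C)C[C@H](NC(=O)CNC(=O)N1C/C(=C\c2ccc(F)cc2)C(=O)/C(=C/c2ccc(F)cc2)C1)B1OC(C)(C)C(C)(C)O1` and compound 3 `CC1(C)OB([C@H](CCc2ccccc2)NC(=O)N2C/C(=C\c3ccc(F)cc3)C(=O)/C(=C/c3ccc(F)cc3)C2)OC1(C)C` on a shared core, with compound 4 `CCC[C@H](NC(=O)N1C/C(=C\c2ccc(F)cc2)C(=O)/C(=C/c2ccc(F)cc2)C1)B1OC(C)(C)C(C)(C)O1` still unmeasured. In a functional assay on HCT-116 cells (Homo sapiens) for antiproliferative activity, read by MTT assay, with a stated time of 72 h (on this read-out lower numbers stand for stronger inhibition and higher numbers for weaker inhibition), compound 3 at 1040 nM lies within the scatter of compound 1 at 639 nM and stands beyond the scatter, on the higher side, of compound 2 at 375 nM in the same read-out.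

Compound 4 departs from compound 3 by one change: methyl in place of phenyl on a saturated chain carbon, three bonds along the chain from an amide-type nitrogen and a boron atom that is, methyl in place of phenyl on a saturated chain carbon, three bonds along the chain from an amide-type nitrogen and a boron atom, or phenethyl to propyl. Within the data shown here, no measured step covers this change directly. The nearest evidence is a 1.7-fold lower number from compound 1 to compound 2 (0.23 log units; within the scatter) and that step, hydrogen in place of isobutyl, sits at another place in the molecule. On that thin basis only a small move toward a lower number is expected in this assay with nothing clearly beyond the scatter. The estimated step is a 1.5-fold lower number from compound 3 to compound 4 (0.17 log units; within the scatter) for now. For compound 4 the estimated value is 700 nM with an expected range of 300 nM to 1600 nM for repeat measurements.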

Compound 4, half-maximal inhibitory concentration: 785 nM
For compound 4 the middle estimate is 1.1-fold (0.05 log units) below the measured one; measured number inside the range.
By their numbers in this assay, from the lowest: compounds 2, 1, 4 and 3 (each within the scatter of the next, the first and the last beyond it).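

In this assay, phenethyl to propyl gives a 1.3-fold lower number from compound 3 to compound 4 (0.12 log units; within the scatter), so compound 3 and compound 4 cannot be told apart on this read-out even though the six-membered aromatic ring is gone from the chain. Among these compounds, this is the first direct comparison at this position: it shows that, on the shared core, a phenyl at the chain end is not needed for a number in this range, and that a plain propyl chain serves as well here. No measurement at hand gives a reason for this outcome.

Among the compounds shown here, this position is covered by only two groups, phenethyl and propyl, so one pair cannot define a trend. As far as these compounds go, whether a longer chain, an amine or a carboxylic acid at this place would move the number beyond the scatter remains open.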